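Isopropyl to cyclobutyl on the sulfonyl sulfur

The compounds below may be only part of what the source reports. "The series", "measured", "known", "first", "only" and "open" are said of these compounds alone.

Three compounds carry numbers in a functional assay on MIA PaCa-2 cells (Homo sapiens) for inhibition, read by MTT assay, with a stated time of 7 days; on this read-out higher numbers stand for weaker inhibition and lower numbers for stronger inhibition. Compound 1 `CCN(CC)S(=O)(=O)c1ccc(S(=O)(=O)N2CCC[C@@H](C(=O)NC3CN(C(=O)OC(C)(C)C)C3)C2)cc1` gives 200 nM. Compound 2 `CC(C)c1noc(N2CCN(C(=O)[C@@H]3CCCN(S(=O)(=O)c4ccc(S(=O)(=O)C(C)C)cc4)C3)CC2)n1` gives 70 nM, the lowest of the three; its gap to compound 1 lies beyond the scatter, and the gap to compound 3 is wider still. Compound 3 `CCOC(=O)[C@@H]1CCCN(S(=O)(=O)c2ccc(S(=N)(=O)N(CC)CC)cc2)C1` gives 2600 nM in this assay and sits far above both. No pair among these three differs in a single place, so no single-point step has been measured in the series so far.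

Compound 4 `CC(C)c1noc(N2CCN(C(=O)[C@@H]3CCCN(S(=O)(=O)c4ccc(S(=O)(=O)C5CCC5)cc4)C3)CC2)n1` is the next one to be run in this assay. Against compound 2 the change is cyclobutyl in place of isopropyl on a sulfonyl sulfur. The rest of the structure is kept. Within the data shown here, with no measured step of this kind to lean on, the expectation for compound 4 rests on compound 2 alone, whose value 70 nM is the reference; the step is expected to be small, within the scatter, with no direction called: a 1.1-fold higher number from compound 2 to compound 4 (0.06 log units; within the scatter). Compound 4 is therefore estimated at 80 nM, in the range 30 nM to 250 nM.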

Compound 4, half-maximal inhibitory concentration: 70 nM
Compound 4: middle estimate off by 1.1-fold (0.06 log units), on the high side, and the stated range covers the measured number.
By their numbers in this assay, from the lowest: compounds 2 and 4 (each within the scatter of the next); then compound 1; then compound 3.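

Cyclobutyl in place of isopropyl on a sulfonyl sulfur gives no change at the digits printed from compound 2 to compound 4 (within the scatter) in this assay, the first single-place step in the series. Among these compounds, on this one pair, the position accepts a four-membered non-aromatic ring of carbon only where isopropyl has no ring, with the read-out unmoved; the earlier compounds, none differing in a single place, could not show this. No measurement shown gives a reason for this flat step.

Still open, from the compounds shown here alone, is how this position responds to a larger carbocycle such as cyclohexyl, a longer chain such as n-butyl, or a group bearing an amine or a carboxylic acid. Going by these compounds, the flat step also rests on a single pair, so whether the same change reads alike on another core remains unknown.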